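Chloro on the Phenyl Ring: What Compound 3 Might Show

The source may hold more compounds than are shown below. What is called first, only, known or untested is meant among the compounds shown, and "the series" means these compounds.

Compound 1 `Cc1nn(C2CCCCC2)c2c1C(c1ccccc1Cl)=NCC(=O)N2` — > 40 mg/kg
Compound 2 `Cc1nn(-c2ccccc2)c2c1C(c1ccccc1)=NCC(=O)N2` — > 40 mg/kg

Of the compounds shown here, two have been tested in a functional assay on the whole organism (strain Holtzman) with Rattus norvegicus as the target; a lower number here means that less compound is needed, a higher number that more compound is needed for the effect. In this assay compound 1 gives > 40 mg/kg, which is a limit of the assay and not a number. Compound 2 likewise gives > 40 mg/kg in this assay, again a limit rather than a measured number. Among the compounds with values here, the only evidence on record is the limit of > 40 mg/kg in this assay, at which 2 of the 2 values shown sit, so the numbers do not separate compound 1 from compound 2, and no step between them can be counted.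

Compound 3 `Cc1nn(-c2ccccc2)c2c1C(c1ccccc1Cl)=NCC(=O)N2` has not yet been measured. It differs from compound 2 in one place: chloro in place of hydrogen on an aromatic carbon. The closest guide is compound 1, which carries the same 2-chlorophenyl group on a different core and gives only a limit in this assay.

Because the limit of > 40 mg/kg in this assay, at which 2 of the 2 values shown sit, is all that the measured values show, the step is expected to stay within the scatter, a number no higher from compound 2 to compound 3 (the limit leaves the size open). Compound 3 is therefore expected to give about 40 mg/kg, with a range from 15 mg/kg to 120 mg/kg, and a fair chance that this assay again reports only a limit.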

Compound 3, minimum effective dose: 20 mg/kg
For compound 3 the middle estimate is 2.0-fold (0.30 log units) above the measured one; the range from low to high includes it.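

Within the data shown here, compound 3 is the first compound here to give a number rather than a limit in this assay, which shows that this position, on an aromatic carbon ortho to a large group, can carry chloro with a dose inside the measured range. Chloro in place of hydrogen gives an at least 2.0-fold lower number from compound 2 to compound 3 (0.30 log units; that floor lies within the scatter), so the step has a floor but no upper size, and that floor does not clear the scatter: the limit of > 40 mg/kg in this assay, at which 2 of the 3 values shown sit. With 2-chlorophenyl present in both, phenyl in place of cyclohexyl on the aromatic nitrogen gives an at least 2.0-fold lower number from compound 1 to compound 3 (0.30 log units; that floor lies within the scatter), which suggests that 2-chlorophenyl alone does not ensure a measured dose, though this floor too stays within the scatter.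

As far as these compounds go, how much lower compound 3 truly lies than compound 2 and compound 1 remains open, as does whether the result is particular to chloro. The compounds shown do not tell how fluoro, bromo, methyl or methoxy would behave on the same carbon, or how a small alkyl group such as methyl would behave on the aromatic nitrogen.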